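The source may hold more compounds than are shown below. What is called first, only, known or untested is meant among the compounds shown, and "the series" means these compounds.

Measured so far in an assay on isolated protein for displacement of a labelled ligand from melanin-concentrating hormone receptor 1 (Homo sapiens); a higher number here means a weaker inhibitor, a lower number a stronger inhibitor:
compound 1, `CCCc1cc(NC)c2cc(NC(=O)/C=C/c3ccc(C(F)(F)F)cc3)ccc2n1`, gives 1.5 nM
compound 2, `CCCc1cc(OC)c2cc(NC(=O)/C=C/c3ccc(C(F)(F)F)cc3)ccc2n1`, gives 26 nM

Among the compounds with values here, compound 2 stands at the highest of the two numbers in this assay; its nearest neighbour is compound 1, and the single measured step, a 17-fold higher number from compound 1 to compound 2 (1.24 log units; beyond the scatter), is large and beyond the scatter. Compound 3, `CCCc1cc(N(C)C)c2cc(NC(=O)/C=C/c3ccc(C(F)(F)F)cc3)ccc2n1`, is not yet measured. Its change from compound 2 is dimethylamino in place of methoxy on an aromatic carbon. Within the data shown here, the one step that bears on this is that from compound 1 to compound 2, where methoxy in place of methylamino raised the number sharply; compound 3 puts an amino group back on the same carbon, though dimethylamino rather than methylamino, so a return toward the lower number of compound 1 is expected, but not necessarily all the way. For compound 3 the expected step is a 4.3-fold lower number from compound 2 to compound 3 (0.64 log units; beyond the scatter). The estimate for compound 3 in this assay is 6 nM, within 1.5 nM to 25 nM.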

Compound 3, half-maximal inhibitory concentration: 43 nM
Compound 3: the middle estimate sits 7.2-fold (0.86 log units) below what was measured; measured number above the stated range.
By their numbers in this assay, from the lowest: compound 1; then compounds 2 and 3 (each within the scatter of the next).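

In this assay, the change on this aromatic carbon, opposite the ring nitrogen, gives a 1.7-fold higher number from compound 2 to compound 3 (0.22 log units; within the scatter), so putting a nitrogen back in place of the oxygen does not by itself recover the number of compound 1. Methyl in place of hydrogen on that nitrogen gives a 29-fold higher number from compound 1 to compound 3 (1.46 log units; beyond the scatter), which shows that one added methyl is enough to lose that number, and of the three compounds only compound 1 keeps a hydrogen on a nitrogen here. The data on hand offer no explanation for this difference.

Still open, from the compounds shown here alone, is whether a plain amino group or an ethylamino group on this carbon would group with compound 1 or with compound 2 and compound 3. Going by these compounds, it is also open whether the same order would hold with a chain other than propyl on the shared core.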